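A few compounds are considered here, and "the series" means these few. Any claim that something is new, unique, unknown or untested is made for them only; others in the source may bear on it.

Of the compounds shown here, three sharing one core have been measured in an ADME assay on MT4 cells (Homo sapiens) for cytotoxicity, read by MTT assay, with a stated time of 5 days; a higher number here means that more compound is tolerated, a lower number that less compound is tolerated. In this assay compound 1 `Cc1ccc(S(=O)(=O)Nc2ccnc(Nc3ccc(C#N)cc3)c2)cc1` gives 14000 nM, compound 2 `N#Cc1ccc(Nc2cc(NS(=O)(=O)c3ccc(C#N)cc3)ccn2)cc1` gives 93400 nM, and compound 3 `N#Cc1ccc(Nc2cc(NS(=O)(=O)c3ccc(C(F)(F)F)cc3)ccn2)cc1` gives 28000 nM. Compound 1 thus holds the lowest of the three numbers: a 2.0-fold higher number from compound 1 to compound 3 (0.30 log units; within the scatter), whereas a 6.7-fold higher number from compound 1 to compound 2 (0.82 log units; beyond the scatter). Between the other two, a 3.3-fold lower number from compound 2 to compound 3 (0.52 log units; beyond the scatter). Compound 4 `N#Cc1ccc(Nc2cc(NS(=O)(=O)c3cc(F)cc(F)c3)ccn2)cc1` has not yet been measured in this assay; it differs from compound 1 in that (3,5-difluorophenyl in place of 4-methylphenyl on a sulfonyl sulfur). The measured steps each exchange a single group within that same part of the molecule, and none of them lowered the number beyond the scatter, so in this assay a small rise, or no change beyond the scatter, is expected. For compound 4 the estimate is 22000 nM, ranging from 9000 nM to 55000 nM, which would mean an expected 1.6-fold higher number from compound 1 to compound 4 (0.20 log units; within the scatter).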

Compound 4, half-maximal cytotoxic concentration: 28600 nM
Compound 4: middle estimate off by 1.3-fold (0.11 log units), on the low side, and the stated range covers the measured number.
By their numbers in this assay, from the lowest: compounds 1, 3 and 4 (each within the scatter of the next, the first and the last beyond it); then compound 2.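

At the sulfonyl sulfur, 3,5-difluorophenyl, the first replacement here with two substituents on the ring, also improves on 4-methylphenyl, giving a 2.0-fold higher number from compound 1 to compound 4 (0.31 log units; beyond the scatter). It does not match 4-cyanophenyl, however, with a 3.3-fold lower number from compound 2 to compound 4 (0.51 log units; beyond the scatter), so compound 2 keeps the highest number of the four. Nothing measured here accounts for these differences.

The compounds shown leave open how a single fluorine on the ring would compare. They also leave open how a ring carrying an amine or a carboxylic acid would behave at this sulfur.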